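Replacing the chloro group on a doubly limited series

The compounds below may be only part of what the source reports. "The series", "measured", "known", "first", "only" and "open" are said of these compounds alone.

Values in a functional assay on HGC-27 cells (Homo sapiens) for cytotoxicity, read by MTT assay, with a stated time of 48 h; a lower number here means a stronger inhibitor, a higher number a weaker inhibitor:
Compound 1 `COc1ccc(/C=C/C(=O)/C=C/c2cc3ccccc3nc2Cl)c(OC)c1`: > 10000 nM (a limit)
Compound 2 `COc1cc(OC)c(/C=C/C(=O)/C=C/c2cc3ccccc3nc2Cl)c(OC)c1`: > 10000 nM (a limit)
Compound 3 `COc1cc(OC)c(/C=C/C(=O)/C=C/c2cc3ccccc3nc2Oc2ccccc2C(C)C)c(OC)c1`: not yet measured

Compound 2 stands at > 10000 nM, which is a limit and not a number. Among the measured compounds shown here, the same holds for the other measured compound, and the series so far amounts to the limit of > 10000 nM in this assay, at which 2 of the 2 values shown sit. The next change is 2-isopropylphenoxy in place of chloro on an aromatic carbon, next to the ring nitrogen. For the measured compounds named here, only one measured step bears on it, a step that the two limits leave unreadable from compound 1 to compound 2, and it involves methoxy in place of hydrogen at another site, so it offers no size to carry over. A readable number for compound 3 could only lie on the stronger side of the limit of compound 2, yet a further limit remains quite possible. The expected step is an at least 2.0-fold lower number from compound 2 to compound 3 (0.30 log units; that floor lies within the scatter), modest and towards stronger inhibition. For compound 3 the estimate is 5000 nM, with an expected range from 1200 nM to 20000 nM.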

Compound 3, half-maximal inhibitory concentration: > 10000 nM
Compound 3 gave a limit, no number; the forecaster's own chance of this, stated with the estimate: 35%; at least 2.0-fold (0.30 log units) between middle value and limit.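

In this assay compound 3 gives > 10000 nM, a limit and not a number. Compound 2 also stands at a limit, so no step can be read between compound 2 and compound 3. The compounds shown leave open whether any change to the shared core gives a readable number, as all stop at one value: the limit of > 10000 nM in this assay, at which 3 of the 3 values shown sit.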